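Chain extension at the methylamino group of compound 1

A few compounds are considered here, and "the series" means these few. Any claim that something is new, unique, unknown or untested is made for them only; others in the source may bear on it.

Compound 1 `CNc1nc(NCc2ccc(C(=O)NC3CCN(Cc4ccc(F)cc4)CC3)cc2)c2cc(C)ccc2n1` carries a methylamino group on the shared core. In a functional assay on HCT-116 cells (Homo sapiens) for inhibition, read by luminescence and resazurin assay, with a stated time of 3 days (on this read-out lower numbers stand for stronger inhibition and higher numbers for weaker inhibition), compound 1 gives 1200 nM, the lowest of the two numbers shown, though only within the scatter of the other. Compound 2 `CCCCNc1nc(NCc2ccc(C(=O)Nc3ccc(F)cc3)cc2)c2ccccc2n1` differs from compound 1 in several places at once; in this assay compound 2 gives 1400 nM, and the two values show no separation. Compound 3 `CNc1ncc(C)c(NCc2ccc(NC(=O)c3ccc(F)cc3)cc2)n1` is recorded in this assay only as a limit: compound 3 sits at > 20000 nM, a limit rather than a number (the limit of > 20000 nM in this assay, at which 1 of the 3 values shown sits).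

Compound 4 `CCCNc1nc(NCc2ccc(C(=O)NC3CCN(Cc4ccc(F)cc4)CC3)cc2)c2cc(C)ccc2n1` is not yet measured. It follows from compound 1 by ethyl in place of hydrogen on a saturated chain carbon bound to a nitrogen on an aromatic ring. Going by the values given here, no measured pair differs in this place alone; compound 1 and compound 2 carry methylamino and butylamino groups but also differ elsewhere, so their close values give only a loose hint. The step from compound 1 to compound 4 is expected to be small, no larger than the scatter, in either direction: a 1.2-fold lower number from compound 1 to compound 4 (0.08 log units; within the scatter). Compound 4 is expected to give 1000 nM, with a range from 400 nM to 3000 nM.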

Compound 4, half-maximal inhibitory concentration: 1600 nM
Compound 4: middle estimate off by 1.6-fold (0.20 log units), on the low side; low and high end bracket the measured number.
By their numbers in this assay, from the lowest: compounds 1, 2 and 4 (each within the scatter of the next). At a limit, above all of these: compound 3.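

Methylamino to propylamino is the first change at this place that can be read alone, with the rest of the molecule unchanged: in this assay the step reads a 1.3-fold higher number from compound 1 to compound 4 (0.12 log units; within the scatter) and leaves the two numbers unseparated. The chain on the saturated carbon bound to a nitrogen on an aromatic ring can therefore grow by ethyl without a measurable shift in this assay, which the pair of compound 1 and compound 2, differing in several places at once, could only hint at. No measured property among the data bears on this step.

Still open, going by these compounds, is whether this flat reading extends to a longer chain at the same place. On these data alone, a chain ending in a primary amine, a carboxylic acid or a hydroxyl group also remains untested here.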